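A few compounds are considered here, and "the series" means these few. Any claim that something is new, unique, unknown or untested is made for them only; others in the source may bear on it.

Measured in a functional assay on NUGC cells (stomach, Homo sapiens) for cytotoxicity; on this read-out higher numbers stand for weaker inhibition and lower numbers for stronger inhibition:
- compound 1 `N#C/N=C1\N(CCCCCOc2ccc(Cl)cc2)C(=O)CN1c1ccncc1`: 2760 nM
- compound 2 `N#C/N=C1\N(CCCCCCOc2ccc(Cl)cc2)C(=O)CN1c1ccncc1`: 386 nM
- compound 3 `N#C/N=C1\N(CCCCCCCOc2ccc(Cl)cc2)C(=O)CN1c1ccncc1`: 926 nM

Of these three, compound 1 has the highest number, and so the weakest inhibition in this assay. Compound 4 `CCC1C(=O)N(CCCCCOc2ccc(Cl)cc2)/C(=N\C#N)N1c1ccncc1` keeps the chain of compound 1 and alters the core instead: ethyl in place of hydrogen on a saturated ring carbon.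

For the measured compounds named here, the only measured steps lie in the chain, where the series gives a 7.2-fold lower number from compound 1 to compound 2 (0.85 log units; beyond the scatter) and a 3.0-fold lower number from compound 1 to compound 3 (0.47 log units; beyond the scatter), followed by a 2.4-fold higher number from compound 2 to compound 3 (0.38 log units; beyond the scatter). All three are modest, though beyond the scatter. None of them touches the saturated ring carbon, so they show only how far numbers in this small series have moved, not which way an ethyl group will push. Going by the values given here, no measured compound carries any group at that carbon. A step of similar modest size is therefore the most that can be anticipated, with a slight lean towards weaker inhibition held only tentatively and a wide margin on either side. The expected change is a 1.3-fold higher number from compound 1 to compound 4 (0.10 log units; within the scatter). For compound 4 the estimated value is 3500 nM, with an expected range of 1000 nM to 12000 nM.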

Compound 4, half-maximal inhibitory concentration: 3040 nM
Beside the measured number, compound 4's estimate is 1.2-fold (0.06 log units) above it; the measured number falls inside the stated range.
By their numbers in this assay, from the lowest: compound 2; then compound 3; then compounds 1 and 4 (each within the scatter of the next).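

In this assay, for the compounds shown here, ethyl in place of hydrogen on the saturated ring carbon gives a 1.1-fold higher number from compound 1 to compound 4 (0.04 log units; within the scatter), the first reading at this position, which lies next to the ring atom that bears a pyridin-4-yl group. The ring carbon therefore carries an ethyl group with no change that can be told from the scatter, unlike the chain, where a 7.2-fold lower number from compound 1 to compound 2 (0.85 log units; beyond the scatter) lies beyond it. Nothing given here explains why the ethyl group leaves the number where it stands.

On these data alone, whether the same carbon would behave alike with a benzyl group, an amine or a carboxylic acid remains open. Also open, as far as these compounds go, is whether ethyl at this position would leave the number unmoved on the chain of compound 2, which stands at 386 nM without it.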